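Swapping the ring amine for dimethylamino in a chalcone series

A few compounds are considered here, and "the series" means these few. Any claim that something is new, unique, unknown or untested is made for them only; others in the source may bear on it.

Of the compounds shown here, three sharing one core have been measured in a functional assay on ECa-109 cells (Homo sapiens) for antiproliferative activity, with a stated time of 72 h; a lower number here means a stronger inhibitor, a higher number a weaker inhibitor. Compound 1 `COc1cc(OC)c(C(=O)/C=C/c2ccccc2Cl)c(O)c1CN(C)CCCN(C)C` gives 3800 nM, compound 2 `CCN(CC)Cc1c(OC)cc(OC)c(C(=O)/C=C/c2ccccc2Cl)c1O` gives 7100 nM, and compound 3 `COc1cc(OC)c(C(=O)/C=C/c2ccccc2Cl)c(O)c1CN1CCCCC1` gives 2500 nM. Compound 3 has the lowest number of the three: it differs from compound 1 only within the scatter, but the step of a 2.8-fold lower number from compound 2 to compound 3 (0.45 log units; beyond the scatter) is beyond it, so compound 3 is a modestly stronger inhibitor than compound 2 in this assay.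

Compound 4 `COc1cc(OC)c(C(=O)/C=C/c2ccccc2Cl)c(O)c1CN(C)C` is not yet measured. Its difference from compound 3 is dimethylamino in place of piperidin-1-yl on a saturated chain carbon bound to an aromatic carbon. The step that bears most on it runs the other way: a 2.8-fold lower number from compound 2 to compound 3 (0.45 log units; beyond the scatter), where an open-chain amine with two ethyl groups gave way to the six-membered ring. The step of a 1.5-fold lower number from compound 1 to compound 3 (0.18 log units; within the scatter) and the step of a 1.9-fold higher number from compound 1 to compound 2 (0.27 log units; within the scatter) both stayed within the scatter, so the three amines span only a narrow band. Since compound 4 returns to an open-chain amine, a modest rise in the number is expected, roughly reversing part of the gain seen in compound 3, though the spread among the measured amines is small enough that no change beyond the scatter would also be unsurprising.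

Compound 4 is therefore expected to give about 4500 nM, with a likely range from 2000 nM to 10000 nM, a step of a 1.8-fold higher number from compound 3 to compound 4 (0.26 log units; within the scatter) in this assay.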

Compound 4, half-maximal inhibitory concentration: 2600 nM
Estimate against measurement, compound 4: 1.7-fold (0.24 log units) above, within the range that was stated.
By their numbers in this assay, from the lowest: compounds 3, 4, 1 and 2 (each within the scatter of the next, the first and the last beyond it).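

In this assay, a 1.0-fold higher number from compound 3 to compound 4 (0.02 log units; within the scatter) shows that at this place, on a saturated chain carbon bound to an aromatic carbon, the piperidin-1-yl ring and its 6 heavy atoms cannot be told apart from dimethylamino, with no ring and 3 heavy atoms, and a 1.5-fold lower number from compound 1 to compound 4 (0.16 log units; within the scatter) likewise shows that the 2-(dimethylamino)ethyl part of the longer amine in compound 1 makes no difference beyond the scatter. Within the data shown here, the earlier step from diethylamino to piperidin-1-yl could have suggested that a ring was what mattered, but a 2.7-fold lower number from compound 2 to compound 4 (0.44 log units; beyond the scatter) shows an open-chain amine making a step of about the same size, which leaves compound 2, with its diethylamino group, as the one compound separated from others beyond the scatter. Nothing measured here accounts for why diethylamino stands apart from compound 3 and compound 4.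

The compounds shown leave open whether other ring amines, such as morpholine with its ring oxygen or the five-membered pyrrolidine, would fall with compound 3 and compound 4 or with compound 2. They also leave open what a primary amine or methylamino would do at this place.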